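The source may hold more compounds than are shown below. What is called first, only, known or untested is meant among the compounds shown, and "the series" means these compounds.

Compound 1 `O=C1/C(=C/c2cccnc2)CN(S(=O)(=O)c2ccc(F)cc2)C/C1=C\c1ccccc1F` is the reference point of this small set. In a functional assay on HepG2 cells (Homo sapiens) for cytotoxicity, read by MTT assay, with a stated time of 24 h (on this read-out higher numbers stand for weaker inhibition and lower numbers for stronger inhibition), compound 1 gives 15600 nM. Compound 2 `O=C1/C(=C/c2cccnc2)CN(S(=O)(=O)c2ccc(Cl)cc2)C/C1=C\c1ccccc1F` carries the change chloro in place of fluoro on an aromatic carbon and in this assay compound 2 gives 12400 nM, a step of a 1.3-fold lower number from compound 1 to compound 2 (0.10 log units; within the scatter). Compound 3 `O=C1/C(=C/c2cccnc2)CN(S(=O)(=O)c2ccc(F)cc2)C/C1=C\c1ccccc1C(F)(F)F` differs from compound 1 in its core by trifluoromethyl in place of fluoro on an aromatic carbon; in this assay compound 3 gives 2340 nM, a step of a 6.7-fold lower number from compound 1 to compound 3 (0.82 log units; beyond the scatter), which leaves compound 3 with the lowest number of the three measured compounds.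

Compound 4 `O=C1/C(=C/c2cccnc2)CN(S(=O)(=O)c2ccc(Cl)cc2)C/C1=C\c1ccccc1C(F)(F)F` is not yet measured. It stands to compound 3 as compound 2 stands to compound 1, through (chloro in place of fluoro on an aromatic carbon), the same change made in two pairs here, at the same place. Within the data shown here, the only precedent is the step of a 1.3-fold lower number from compound 1 to compound 2 (0.10 log units; within the scatter), so the step from compound 3 to compound 4 is expected to be a 1.2-fold lower number from compound 3 to compound 4 (0.09 log units; within the scatter), resting on that earlier pair alone. On that basis compound 4 is estimated at 1900 nM, between 900 nM and 4000 nM.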

Compound 4, half-maximal inhibitory concentration: 3620 nM
The estimate for compound 4 lay 1.9-fold (0.28 log units) below the measured number; the measured number falls inside the stated range.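

In this assay, the change from 4-fluorophenyl to 4-chlorophenyl stays within the scatter on both cores, with a 1.5-fold higher number from compound 3 to compound 4 (0.19 log units; within the scatter), so it carries over as a step too small to read: the same change on two cores in this assay, a 1.3-fold lower number (0.10 log units; within the scatter) from compound 1 to compound 2 and a 1.5-fold higher number (0.19 log units; within the scatter) from compound 3 to compound 4, 1.9-fold (0.29 log units) apart, within the scatter of two such steps. The trifluoromethyl change keeps its direction when the chloro group is present, with a 3.4-fold lower number from compound 2 to compound 4 (0.53 log units; beyond the scatter), and the two steps agree within the scatter: the same change on two cores in this assay, a 6.7-fold lower number (0.82 log units; beyond the scatter) from compound 1 to compound 3 and a 3.4-fold lower number (0.53 log units; beyond the scatter) from compound 2 to compound 4, 1.9-fold (0.29 log units) apart, within the scatter of two such steps. Among these compounds, with only two pairs per change, all in one assay, this does not show that either step would hold on any other core.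

Open, going by these compounds, is how an amine or a methoxy group would read in place of the fluoro or chloro. Also open, on these data alone, is whether a nitrile in place of the trifluoromethyl would give a comparable step.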